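Moving the Pyridine Nitrogen Again: What to Expect for Compound 3

The compounds below may be only part of what the source reports. "The series", "measured", "known", "first", "only" and "open" are said of these compounds alone.

Compound 1 has the structure `Cc1cccc(-c2noc([C@H](C)NC(=O)c3cc(C(F)(F)F)nn3C)n2)n1`. In an assay on T-REx-293 cells for inhibition of potassium channel subfamily T member 1 (Homo sapiens), read by patch clamp (on this read-out higher numbers stand for weaker inhibition and lower numbers for stronger inhibition), compound 1 sits at a limit, > 30000 nM.
Compound 2 has the structure `Cc1cncc(-c2noc([C@H](C)NC(=O)c3cc(C(F)(F)F)nn3C)n2)c1`. In this assay compound 2 gives 1370 nM.

Going by the values given here, compound 2 holds the only number among the two values; compound 1 is a limit only (the limit of > 30000 nM in this assay, at which 1 of the 2 values shown sits). Among the compounds with values here, the one measured step, an at least 21-fold lower number from compound 1 to compound 2 (1.34 log units; beyond the scatter), shows that rearranging methyl and nitrogen within the six-membered ring can change inhibition a great deal. Compound 3, `Cc1cc(-c2noc([C@H](C)NC(=O)c3cc(C(F)(F)F)nn3C)n2)ccn1`, carries the change (2-methylpyridin-4-yl in place of 5-methylpyridin-3-yl on an aromatic carbon). Within the data shown here, only that single large step bears on it, and it gives no sign of direction, so a modest step either way is expected, here written as a 2.2-fold higher number from compound 2 to compound 3 (0.34 log units; beyond the scatter). Compound 3 is therefore estimated at 3000 nM, within 700 nM to 15000 nM.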

Compound 3, half-maximal inhibitory concentration: 165 nM
For compound 3 the middle estimate is 18-fold (1.26 log units) above the measured one; measured number outside the range, below it.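

Even with the same atoms on the same aromatic carbon, the arrangement in 2-methylpyridin-4-yl gives an 8.3-fold lower number from compound 2 to compound 3 (0.92 log units; beyond the scatter), making compound 3 the strongest inhibitor of the three. Against 6-methylpyridin-2-yl, the change gives an at least 180-fold lower number from compound 1 to compound 3 (2.25 log units; beyond the scatter), so this position responds strongly to where the ring nitrogen and methyl group sit. That size is only a bound, as compound 1 gives a limit rather than a number: the limit of > 30000 nM in this assay, at which 1 of the 3 values shown sits.

Still open, as far as these compounds go, is how much of the gain depends on the methyl group itself. A plain pyridin-4-yl or a 2-aminopyridin-4-yl at this position would help to answer that.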